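The compounds below may be only part of what the source reports. "The series", "measured", "known", "first", "only" and "open" are said of these compounds alone.

In an ADME assay on Huh-7 cells (Homo sapiens) for cytotoxicity, read by resazurin assay, with a stated time of 48 h (a higher number here means that more compound is tolerated, a lower number that less compound is tolerated), compound 1 (`COC(=O)[C@H](C)NC(=O)CCC(=O)/C=C/c1ccccc1`) gives 1320 nM, within the scatter of its two measured relatives: compound 2 (`COC(=O)[C@H](C)NC(=O)CCC(=O)/C=C/c1cccnc1`) gives 2110 nM and compound 3 (`COC(=O)[C@@H](NC(=O)CCC(=O)/C=C/c1cccnc1)C(C)C`) gives 1570 nM. Compound 4 (`CC(C)[C@H](NC(=O)CCC(=O)/C=C/c1ccccc1)C(=O)O`) remains unmeasured, and it differs from compound 1 as follows: 1-carboxy-2-methylpropyl in place of 1-(methoxycarbonyl)ethyl on an amide-type nitrogen. For the measured compounds named here, only one measured step bears on this change: isopropyl in place of methyl gave a 1.3-fold lower number from compound 2 to compound 3 (0.13 log units; within the scatter), which lies within the scatter. Going by the values given here, no measured compound carries the carboxy group in place of methoxycarbonyl, so that part of the change is untested. A modest move to a higher number in this assay is tentatively expected, a 2.3-fold higher number from compound 1 to compound 4 (0.36 log units; beyond the scatter). For compound 4 the estimated value is 3000 nM, with an expected range from 1000 nM to 15000 nM.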

Compound 4, half-maximal cytotoxic concentration: > 100000 nM
Compound 4: only a limit was reported (the forecaster's own chance of this, stated with the estimate: 15%); middle value at least 33-fold (1.52 log units) from the limit.
By their numbers in this assay, from the lowest: compounds 1, 3 and 2 (each within the scatter of the next). At a limit, above all of these: compound 4.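

In this assay, for the compounds shown here, the change on the amide-type nitrogen, 1-carboxy-2-methylpropyl in place of 1-(methoxycarbonyl)ethyl, gives an at least 75-fold higher number from compound 1 to compound 4 (1.87 log units; beyond the scatter) and so shows that this position can carry a step far beyond the scatter, which no earlier step did. The reading for compound 4 is a limit of the assay, not a number: the limit of > 100000 nM in this assay, at which 1 of the 4 values shown sits.

The compounds shown do not separate the carboxy group from the isopropyl part of this change, as the only isopropyl step (a 1.3-fold lower number from compound 2 to compound 3 (0.13 log units; within the scatter)) has pyridin-3-yl in place of phenyl. From the compounds shown here alone, whether an ethyl ester or a primary amide in place of the carboxy group would give a similar step also stays open.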